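The compounds below may be only part of what the source reports. "The series", "measured", "known", "first", "only" and "open" are said of these compounds alone.

Measured so far:
compound 1 `O=C1NC(=O)/C(=C/c2ccc(OCc3csc(-c4ccccc4)n3)cc2)S1` in a functional assay on the whole organism (strain Wistar) with Rattus norvegicus as the target, with a stated time of 15 days, at a dose of 30 mg/kg by the oral route; a higher number here means a stronger effect of the compound at the dose given, a lower number a weaker effect: 40.3%
compound 2 `Cc1ccc(-c2nnc(SCCOc3ccc(/C=C4\SC(=O)NC4=O)cc3)[nH]2)cc1` in this assay: 40.3%

Compound 2 stands level with compound 1 at the digits shown; the two values lie within the scatter of each other, so no order between them is claimed. Among the compounds with values here, no step between measured compounds that differ in one place is available. The next compound is compound 3 `COc1ccc(-c2nnc(SCCOc3ccc(/C=C4\SC(=O)NC4=O)cc3)[nH]2)cc1`. It differs from compound 2 by methoxy in place of methyl on an aromatic carbon. Within the data shown here, with only two level values at hand, no step beyond the scatter is expected in this assay; the estimated step is a number 0.3 percentage points lower from compound 2 to compound 3 (within the scatter). Compound 3 is expected to give 40%, in the range 25% to 55%.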

Compound 3, a percentage reported as activity, at one dose (the size of the read-out at that dose, not a potency): 59.5%
Beside the measured number, compound 3's estimate is 19.5 percentage points below it; measured number outside the range, above it.
By their numbers in this assay, from the lowest: compounds 1 and 2 (each within the scatter of the next); then compound 3.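

In this assay, within the data shown here, the change from 4-methylphenyl to 4-methoxyphenyl gives a number 19.2 percentage points higher from compound 2 to compound 3 (beyond the scatter) and is the first step beyond the scatter, so the read-out responds to the group on this aromatic carbon, para to a large group. This rests on one pair, and compound 1 differs from both compounds in more than one place. Nothing available here accounts for the step. Open, as far as these compounds go, is whether hydrogen, ethoxy, fluorine or an amine in this place would give a higher or lower read-out.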